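The compounds below may be only part of what the source reports. "The series", "measured", "known", "first", "only" and "open" are said of these compounds alone.

Going by the values given here, in a functional assay on HT-29 cells (Homo sapiens) for inhibition, read by sulforhodamine B assay, with a stated time of 48 h (on this read-out lower numbers stand for stronger inhibition of growth and higher numbers for weaker inhibition of growth), compound 1 `CC1(/C=C/c2ccccc2)C=CC(=O)O1` gives 123000 nM, which places it at the high end of the three numbers measured so far. Compound 3 `CC1(/C=C/c2cccc(O)c2)C=CC(=O)O1` gives 97400 nM, and the scatter of the measurement cannot separate it from compound 1. Among the compounds with values here, compound 2 `CC1(/C=C/c2ccc(C(F)(F)F)cc2)C=CC(=O)O1` gives 12300 nM, the only number clearly apart from that of compound 1.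

Compound 4 `COc1ccccc1/C=C/C1(C)C=CC(=O)O1` has not yet been measured. It keeps the core of compound 1 and differs in one place: methoxy in place of hydrogen on an aromatic carbon. Within the data shown here, two measured steps bear on this change, since each also replaces a hydrogen on an aromatic carbon. Trifluoromethyl in place of hydrogen gives a 10-fold lower number from compound 1 to compound 2 (1.00 log units; beyond the scatter), while hydroxy in place of hydrogen gives a 1.3-fold lower number from compound 1 to compound 3 (0.10 log units; within the scatter).

Methoxy, like the hydroxy of compound 3 at 97400 nM, joins the ring through oxygen, so the smaller step is the closer guide. Among the measured compounds shown here, still, no measured compound carries a group ortho to a group of 9 heavy atoms, so the expectation must stay wide. A small move toward a lower number is expected, most likely not beyond the scatter, and the estimated step is a 1.4-fold lower number from compound 1 to compound 4 (0.16 log units; within the scatter). The estimated value for compound 4 is 85000 nM, with an expected range from 30000 nM to 170000 nM.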

Compound 4, concentration for total growth inhibition: 30800 nM
The estimate for compound 4 lay 2.8-fold (0.44 log units) above the measured number, and the stated range covers the measured number.
By their numbers in this assay, from the lowest: compound 2; then compound 4; then compounds 3 and 1 (each within the scatter of the next).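

In this assay, methoxy on an aromatic carbon ortho to a group of 9 heavy atoms gives a 4.0-fold lower number from compound 1 to compound 4 (0.60 log units; beyond the scatter) and so shows that a group at this place can move the number beyond the scatter. The hydroxy of compound 3, which does not stand at this place, gives a 1.3-fold lower number from compound 1 to compound 3 (0.10 log units; within the scatter) and stays within the scatter, so a group joined to the ring through oxygen does not always leave the number within the scatter. Nothing measured here explains why the methoxy step is the larger of these two.

On these data alone, compounds 3 and 4 differ in both the group and its place, so it remains open whether the group or the place sets the size of the step, and a hydroxy at the place of the methoxy would help to separate the two. As far as these compounds go, how an amine, a carboxylic acid or a longer chain such as ethoxy would compare with methoxy at this same aromatic carbon also remains open.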